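Trading bromo for trifluoromethyl in an antiproliferative pair

The source may report more compounds than this note shows. Statements on the series, on what has been measured and on what is new or still open speak of the compounds shown alone.

Compound 1 `Fc1ccc(-c2nn(-c3ccccc3)cc2-c2nc3cc(C(F)(F)F)ccc3[nH]2)cc1` gives 2340 nM
Compound 2 `Clc1ccc(-c2nn(-c3ccccc3)cc2-c2nc3cc(Br)ccc3[nH]2)cc1` gives 2170 nM

In a functional assay on A549 cells (Homo sapiens) for antiproliferative activity, read by MTT assay, with a stated time of 48 h (a lower number here means a stronger inhibitor, a higher number a weaker inhibitor), compound 2 gives 2170 nM and compound 1 gives 2340 nM in the same test. These two values lie within the usual scatter of repeated measurements, so compound 2 stands level with compound 1 and no ranking can be drawn.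

Compound 3 `FC(F)(F)c1ccc2[nH]c(-c3cn(-c4ccccc4)nc3-c3ccc(Cl)cc3)nc2c1` has not yet been measured. It differs from compound 2 in one place. The change trifluoromethyl in place of bromo on an aromatic carbon puts trifluoromethyl in place of bromo on an aromatic carbon of a six-membered aromatic ring of carbon only. Among the measured compounds shown here, no pair of measured compounds differs in just one place, so there is no direct precedent for the size of this step. The only indirect hint is that compound 1 also carries trifluoromethyl and gives 2340 nM within the scatter of compound 2. The estimated 1.0-fold higher number from compound 2 to compound 3 (0.02 log units; within the scatter) is therefore expected to stay within the scatter in this assay with no direction favoured. For compound 3 the estimated value is 2250 nM with an expected range from 1100 nM to 4600 nM in this test.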

Compound 3, half-maximal inhibitory concentration: 3360 nM
Estimate against measurement, compound 3: 1.5-fold (0.17 log units) below, and the stated range covers the measured number.
By their numbers in this assay, from the lowest: compounds 2, 1 and 3 (each within the scatter of the next).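

In this assay, among the compounds shown here, the step of a 1.5-fold higher number from compound 2 to compound 3 (0.19 log units; within the scatter) gives the first direct comparison at this position, and trifluoromethyl, with 4 heavy atoms, stands level with bromo, with 1 heavy atom, on this aromatic carbon of the fused system of two rings. The step of a 1.4-fold higher number from compound 1 to compound 3 (0.16 log units; within the scatter) adds a second single change elsewhere in the molecule, chloro in place of fluoro on an aromatic carbon, and this pair also stands level. No accompanying measurement bears on why neither change separates its pair.

Going by these compounds, the three compounds carry only bromo or trifluoromethyl at this position, so it remains open whether an amine, a carboxylic acid or a longer chain there would move the number beyond the scatter. On these data alone, it also remains open whether these two level comparisons would hold with different groups elsewhere on the shared core.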